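Ring Size at the Chain End of Compound 3

A few compounds are considered here, and "the series" means these few. Any claim that something is new, unique, unknown or untested is made for them only; others in the source may bear on it.

Three measured compounds share one core and differ only in the aryl group on an aromatic nitrogen. In a functional assay on MKN-45 cells (Homo sapiens) for cytotoxicity, read by MTT assay, with a stated time of 72 h (on this read-out lower numbers stand for stronger inhibition and higher numbers for weaker inhibition), compound 1 `COc1cc2c(Oc3ccc(NC(=O)c4nn(-c5cccc(F)c5)c(=O)c5ccccc45)cc3F)ccnc2cc1OCCCN1CCCC1` gives 160 nM. Compound 2 `COc1cc2c(Oc3ccc(NC(=O)c4nn(-c5ccc(Br)cc5)c(=O)c5ccccc45)cc3F)ccnc2cc1OCCCN1CCCC1` gives 230 nM in this assay, and compound 3 `COc1ccc(-n2nc(C(=O)Nc3ccc(Oc4ccnc5cc(OCCCN6CCCC6)c(OC)cc45)c(F)c3)c3ccccc3c2=O)cc1` gives 1320 nM. Compound 3 stands highest of the three numbers. The steps run a 5.7-fold higher number from compound 2 to compound 3 (0.76 log units; beyond the scatter) and an 8.3-fold higher number from compound 1 to compound 3 (0.92 log units; beyond the scatter), whereas a 1.4-fold higher number from compound 1 to compound 2 (0.16 log units; within the scatter).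

Compound 4 `COc1ccc(-n2nc(C(=O)Nc3ccc(Oc4ccnc5cc(OCCCN6CCCCC6)c(OC)cc45)c(F)c3)c3ccccc3c2=O)cc1` differs from compound 3 by piperidin-1-yl in place of pyrrolidin-1-yl on a saturated chain carbon, three bonds along the chain from an oxygen on an aromatic ring. None of the three measured steps touches this part of the molecule: all of them concern the aryl group on the aromatic nitrogen, and the chain ending in the saturated ring is the same in compound 1, compound 2 and compound 3. Within the data shown here, no measured step therefore bears on the change from compound 3 to compound 4, and the data give no indication of a direction. The author expects no step beyond the scatter, namely a 1.0-fold lower number from compound 3 to compound 4 (0.01 log units; within the scatter). For compound 4 in this assay the estimate is accordingly 1300 nM, with an expected range from 500 nM to 3500 nM, the width reflecting that nothing measured speaks to this exchange.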

Compound 4, half-maximal inhibitory concentration: 950 nM
Estimate against measurement, compound 4: 1.4-fold (0.14 log units) above; low and high end bracket the measured number.
By their numbers in this assay, from the lowest: compounds 1 and 2 (each within the scatter of the next); then compounds 4 and 3 (each within the scatter of the next).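

In this assay, piperidin-1-yl in place of pyrrolidin-1-yl at the end of the chain gives a 1.4-fold lower number from compound 3 to compound 4 (0.14 log units; within the scatter), so this first reading of the position does not separate the six-membered ring from the five-membered one. The earlier steps shown here held this chain end fixed and varied only the aryl group on the aromatic nitrogen, where an 8.3-fold higher number from compound 1 to compound 3 (0.92 log units; beyond the scatter); among the steps that start from or lead to compound 3, that aryl exchange lies beyond the scatter, whereas the ring exchange at the chain end stays within it. Nothing available gives a reason for this outcome at the chain end.

From the compounds shown here alone, the exchange has been read only with the 4-methoxyphenyl group in place, so it remains open whether the same ring exchange would give a similar result with the 3-fluorophenyl or 4-bromophenyl group on the aromatic nitrogen. Also open, going by these compounds, is how the number would respond to a morpholine ring or a dimethylamino group at the chain end, or to a longer chain than 3-(piperidin-1-yl)propyl.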